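A few compounds are considered here, and "the series" means these few. Any claim that something is new, unique, unknown or untested is made for them only; others in the source may bear on it.

Working notes on the series in a functional assay on MDA-MB-231 cells (Homo sapiens) for antiproliferative activity, read by MTT assay, with a stated time of 24 h; a lower number here means a stronger inhibitor, a higher number a weaker inhibitor. Compound 3 `COc1cccc(Nc2ccnc(N3CCN(C(=O)Nc4ccc(C(F)(F)F)cc4)CC3)n2)c1` gives 1240 nM. Compound 1 `O=C(Nc1ccc(C(F)(F)F)cc1)N1CCN(c2nccc(Oc3cc(Cl)cc(Cl)c3)n2)CC1` gives 1540 nM. Among the measured compounds shown here, the only measured single-place step, a 1.2-fold lower number from compound 1 to compound 3 (0.09 log units; within the scatter), lies within the scatter, so these two sit level. Compound 2 `O=C(Nc1ccc(Cl)cc1Cl)N1CCN(c2nccc(NCc3ccccc3)n2)CC1` gives 9790 nM, a clearly higher number than either.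

Compound 4 `COc1cccc(Nc2ccnc(N3CCN(C(=O)Nc4ccc(Cl)cc4Cl)CC3)n2)c1` differs from compound 3 at one place, with 2,4-dichlorophenyl in place of 4-(trifluoromethyl)phenyl on an amide-type nitrogen. For the measured compounds named here, no measured step isolates this change. Going by the values given here, the one step available exchanges a different group, (3-methoxyphenyl)amino in place of 3,5-dichlorophenoxy on an aromatic carbon, and it bears only indirectly: that position changed with no shift beyond the scatter.

Among the compounds with values here, compound 2 is the only measured compound carrying 2,4-dichlorophenyl, but it also differs from compound 3 at that second place, so the value of compound 2 at 9790 nM cannot be credited to 2,4-dichlorophenyl alone. It gives only a weak lean toward a higher number. The expected change is therefore modest and upward, near the edge of the scatter, estimated as a 2.1-fold higher number from compound 3 to compound 4 (0.32 log units; beyond the scatter). For compound 4 the estimate is 2600 nM, with an expected range of 900 nM to 7500 nM.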

Compound 4, half-maximal inhibitory concentration: 11300 nM
Beside the measured number, compound 4's estimate is 4.3-fold (0.64 log units) below it; measured number outside the range, above it.
By their numbers in this assay, from the lowest: compounds 3 and 1 (each within the scatter of the next); then compounds 2 and 4 (each within the scatter of the next).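

In this assay, among the compounds shown here, the place on the amide-type nitrogen now has its own measured step: 2,4-dichlorophenyl in place of 4-(trifluoromethyl)phenyl gives a 9.1-fold higher number from compound 3 to compound 4 (0.96 log units; beyond the scatter) and so goes beyond the scatter, which the one earlier step, at the other place on the shared core, did not do. With 2,4-dichlorophenyl held fixed, 3-methoxyphenyl in place of benzyl on a nitrogen on an aromatic ring gives a 1.2-fold higher number from compound 2 to compound 4 (0.06 log units; within the scatter) and leaves the two compounds level, so among the compounds shown the only single-place step beyond the scatter is the one at the amide-type nitrogen. Nothing at hand gives a reason for the size of this step.

The compounds shown leave open whether the higher number follows from losing trifluoromethyl or from gaining the two chlorines, a question that a single-chlorine group such as 4-chlorophenyl on the same nitrogen could help separate. Also open, going by these compounds, is whether the same exchange carries over when 3,5-dichlorophenoxy occupies the other place, and how an amine or a carboxylic acid on that phenyl ring would read.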